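Swapping two chlorines for two fluorines on a chalcone-type scaffold

The source may report more compounds than this note shows. Statements on the series, on what has been measured and on what is new or still open speak of the compounds shown alone.

Three compounds share a core in which a pyrazole ring carries a methoxy-bearing phenyl ring on one side and, through a two-carbon double bond, a carbonyl with a second aryl ring on the other. Compound 1 `COc1ccc(-c2cc(/C=C/C(=O)c3ccc(N)cc3)[nH]n2)cc1` gives 1890 nM in a functional assay on SN12C cells (Homo sapiens) for inhibition, read by sulforhodamine B assay, with a stated time of 48 h; a higher number here means a weaker inhibitor of growth, a lower number a stronger inhibitor of growth. Compound 2 `COc1cc(-c2cc(/C=C/C(=O)c3ccc(Cl)c(Cl)c3)[nH]n2)cc(OC)c1OC` gives 13700 nM in this assay, the highest of the three numbers, so it is the weakest growth inhibitor here. Compound 3 `COc1ccc(C(=O)/C=C/c2cc(-c3cc(OC)c(OC)c(OC)c3)n[nH]2)cc1OC` gives 1540 nM in this assay. Among the measured compounds shown here, the only single change measured at the carbonyl carbon, an 8.9-fold lower number from compound 2 to compound 3 (0.95 log units; beyond the scatter), replaced one halogenated ring with a methoxy-bearing one.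

Compound 4 `COc1cc(-c2cc(/C=C/C(=O)c3ccc(F)c(F)c3)[nH]n2)cc(OC)c1OC` differs from compound 2 as follows: 3,4-difluorophenyl in place of 3,4-dichlorophenyl on a carbonyl carbon. For the measured compounds named here, no measured step compares two halogenated rings at this place, so the step from compound 2 to compound 3 is only a loose guide, and the change here is smaller in kind. A step of a 2.0-fold lower number from compound 2 to compound 4 (0.29 log units; within the scatter) is expected, at the edge of the scatter, and compound 4 is estimated at 7000 nM, with a range from 2500 nM to 20000 nM in this assay.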

Compound 4, concentration for 50% growth inhibition: 3370 nM
The estimate for compound 4 lay 2.1-fold (0.32 log units) above the measured number; low and high end bracket the measured number.
By their numbers in this assay, from the lowest: compounds 3, 1 and 4 (each within the scatter of the next, the first and the last beyond it); then compound 2.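

At this place, on a carbonyl carbon, two halogenated rings can now be compared directly: in this assay there is a 4.1-fold lower number from compound 2 to compound 4 (0.61 log units; beyond the scatter) and this shows that the choice of halogen alone can move the number beyond the scatter. The 3,4-difluorophenyl ring does not match the 3,4-dimethoxyphenyl ring, as a 2.2-fold higher number from compound 3 to compound 4 (0.34 log units; beyond the scatter) shows, so among these three groups 3,4-dimethoxyphenyl gives the lowest number, 3,4-dichlorophenyl the highest and 3,4-difluorophenyl an intermediate one. No measurement shown here explains why the two halogens differ.

The compounds shown leave open where a ring bearing a trifluoromethyl group, a nitrile or a single fluorine would fall in this order. They also leave open whether the same order holds on the core of compound 1, which carries a different methoxy-bearing ring.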